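Truncating the oxime side chain of compound 3 to a hydroxymethyl

This account rests on a few compounds, and the source may have more. Where it says the series, first, only, none or still open, it means among the compounds named here.

Measured compounds:
compound 1 `COC(=O)CCCc1onc(NS(=O)(=O)c2ccc(C(C)(C)C)cc2)c1Sc1cccc(OC)c1`: 310 nM
compound 2 `CCc1onc(NS(=O)(=O)c2ccc(C(C)(C)C)cc2)c1Sc1cccc(OC)c1`: 2800 nM
compound 3 `COc1cccc(Sc2c(NS(=O)(=O)c3ccc(C(C)(C)C)cc3)noc2CCC/C=N/O)c1`: 85 nM

In an assay on COS-7 cells for displacement of a labelled ligand from Endothelin receptor type B (Sus scrofa) (on this read-out lower numbers stand for stronger inhibition and higher numbers for weaker inhibition), compound 3 stands lowest of the three, with compound 1 at a 3.6-fold lower number from compound 1 to compound 3 (0.56 log units; beyond the scatter) reversed as its nearest neighbour and compound 2 as the furthest. Compound 4 `COc1cccc(Sc2c(NS(=O)(=O)c3ccc(C(C)(C)C)cc3)noc2CO)c1` is not yet measured; it differs from compound 3 by one oxygen atom in place of a group of 5 heavy atoms (3 carbon, 1 nitrogen, 1 oxygen; no ring), on a saturated chain carbon bound to an aromatic carbon. Among the compounds with values here, two measured steps bear on this: a 33-fold lower number from compound 2 to compound 3 (1.52 log units; beyond the scatter), and a 9.0-fold higher number from compound 1 to compound 2 (0.96 log units; beyond the scatter). Both show that shortening or stripping the side chain raises the number in this assay, so for compound 4 a higher number, a large step, is expected: an 18-fold higher number from compound 3 to compound 4 (1.25 log units; beyond the scatter). The estimate for compound 4 is 1500 nM, with a range from 400 nM to 6000 nM.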

Compound 4, half-maximal inhibitory concentration: 560 nM
Beside the measured number, compound 4's estimate is 2.7-fold (0.43 log units) above it; the range from low to high includes it.
By their numbers in this assay, from the lowest: compound 3; then compounds 1 and 4 (each within the scatter of the next); then compound 2.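

In this assay hydroxy in place of methyl gives a 5.0-fold lower number from compound 2 to compound 4 (0.70 log units; beyond the scatter) on this saturated chain carbon, so the atom placed there matters, and not only the reach of the chain. The oxime chain is still not matched, as a 6.6-fold higher number from compound 3 to compound 4 (0.82 log units; beyond the scatter) shows. With a 1.8-fold higher number from compound 1 to compound 4 (0.26 log units; within the scatter) hydroxy and 2-(methoxycarbonyl)ethyl cannot be told apart in this assay.

No measurement shown explains these differences. As far as these compounds go, whether an amine or a carboxylic acid on this carbon, or on a longer chain, would reach the oxime's value remains open.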